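Fluorine Added to Compound 1: Expecting Compound 4

The source may hold more compounds than are shown below. What is called first, only, known or untested is meant among the compounds shown, and "the series" means these compounds.

Measured so far in an ADME assay on the whole organism with Oryza sativa as the target, tested at 10 uM; on this read-out lower numbers stand for a stronger effect and higher numbers for a weaker effect at the one concentration tested:
compound 1 `C[C@H](NC(=O)Nc1ccccc1F)c1ccccc1` gives 65%
compound 2 `C[C@H](NC(=O)Nc1ccccc1Cl)c1ccccc1` gives 106%
compound 3 `C[C@H](NC(=O)Nc1cccc(F)c1F)c1ccccc1` gives 100%

Among these three numbers compound 1 stands lowest. Its nearest neighbour is compound 3, and the step of a number 35 percentage points higher from compound 1 to compound 3 (beyond the scatter) lies beyond the scatter. Further off is compound 2, and the step of a number 41 percentage points higher from compound 1 to compound 2 (beyond the scatter) also lies beyond the scatter. Both changes that have been measured on the shared core of compound 1 thus moved the read-out upward by a large amount.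

Compound 4 `C[C@H](NC(=O)Nc1c(F)cccc1F)c1ccccc1` has not yet been measured. It differs from compound 1 in one place: fluoro in place of hydrogen on an aromatic carbon The fluoro enters ortho to a large group and meta to a fluoro group. The measured step that bears most directly on it is a number 35 percentage points higher from compound 1 to compound 3 (beyond the scatter), the same kind of change, fluoro in place of hydrogen, at another aromatic carbon of the same ring. The chloro swap, a number 41 percentage points higher from compound 1 to compound 2 (beyond the scatter), points the same way. A large upward step is therefore expected in this assay for compound 4, namely a number 30 percentage points higher from compound 1 to compound 4 (beyond the scatter). The estimate for compound 4 is 95%, with a range from 70% to 115%.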

Compound 4, a percentage reported as activity, at one concentration (the size of the read-out at that concentration, not a potency): 99%
The estimate for compound 4 lay 4 percentage points below the measured number; low and high end bracket the measured number.
By their numbers in this assay, from the lowest: compound 1; then compounds 4, 3 and 2 (each within the scatter of the next).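

In this assay, fluoro in place of hydrogen ortho to a large group and meta to a fluoro group gives a number 34 percentage points higher from compound 1 to compound 4 (beyond the scatter), so this position answers much as the other aromatic carbon of the same ring did, where the same swap gave a number 35 percentage points higher from compound 1 to compound 3 (beyond the scatter). Compound 4 and compound 3 lie within the scatter of each other, so across these two places the read-out does not separate one site of the added fluoro from the other, and compound 1 remains apart from all three of its single-change partners by more than the scatter. No measurement at hand explains why the number rises at either place.

The compounds shown leave open whether a group other than fluoro at this position, such as a methoxy group, a nitrile or an amine, would also move the read-out upward, or whether any replacement here could bring it below that of compound 1. Within the data shown here, they also leave open how the ring would read with a hydrogen in place of the one fluoro that compound 1 carries.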